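Benzyl on the ring oxygen of compound 2

A few compounds are considered here, and "the series" means these few. Any claim that something is new, unique, unknown or untested is made for them only; others in the source may bear on it.

Measured so far in a functional assay on PC-3 cells (Homo sapiens) for antiproliferative activity, read by MTT assay, with a stated time of 48 h; on this read-out higher numbers stand for weaker inhibition and lower numbers for stronger inhibition:
compound 1 `CC1(C)Cc2c(ccc(C(=O)/C=C/c3cn(-c4ccccc4)nc3-c3ccc([N+](=O)[O-])cc3)c2OCc2ccccc2)O1` gives 62300 nM
compound 2 `COc1ccc(/C=C/C(=O)c2ccc(O)c3c2OC(C)(C)C3)cc1` gives 48400 nM
compound 3 `COc1ccc(-c2nn(-c3ccccc3)cc2/C=C/C(=O)c2ccc3c(c2OCc2ccccc2)CC(C)(C)O3)cc1` gives 18400 nM

Compound 2 stands second highest of the three numbers. Its nearest neighbour is compound 1, whose number is higher but within the scatter, so no order between the two can be read. Compound 3 gives a lower number beyond the scatter, and compound 2 is therefore not the compound with the lowest number here.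

Compound 4 `COc1ccc(/C=C/C(=O)c2ccc(OCc3ccccc3)c3c2OC(C)(C)C3)cc1` is not yet measured. It differs from compound 2 by benzyl in place of hydrogen on an oxygen on an aromatic ring; cut one bond further out, the change reads hydroxy to benzyloxy.

Among the compounds with values here, the single measured step, a 3.4-fold lower number from compound 1 to compound 3 (0.53 log units; beyond the scatter), alters the substituent on the distal aromatic ring and leaves the oxygen in question untouched, so it does not bear on this change. Within the data shown here, compounds 1 and 3 both carry the benzyl on the corresponding oxygen, but they differ from compound 2 in several further places, and no single-point step between them and compound 2 exists. The benzyl change is thus without direct precedent in this set.

Among the measured compounds shown here, with no bearing step, a small move is expected in this assay for compound 4, modestly downward, as a 1.6-fold lower number from compound 2 to compound 4 (0.21 log units; within the scatter). Compound 4 is estimated at 30000 nM, within 10000 nM to 90000 nM.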

Compound 4, half-maximal inhibitory concentration: 13500 nM
The estimate for compound 4 lay 2.2-fold (0.35 log units) above the measured number; measured number inside the range.
By their numbers in this assay, from the lowest: compounds 4 and 3 (each within the scatter of the next); then compounds 2 and 1 (each within the scatter of the next).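

In this assay, within the data shown here, replacing hydroxy with benzyloxy on the aromatic ring gives a 3.6-fold lower number from compound 2 to compound 4 (0.55 log units; beyond the scatter), the first single-change reading at this oxygen, as the earlier step concerned only the substituent on the distal aromatic ring. On the core of compound 2, the free hydroxy is therefore not needed for a lower number in this assay, and the seven-carbon benzyl group is accepted at this position, with a change beyond the scatter. No available evidence explains the step, so this remains a structure-activity observation from one pair of compounds.

Open, as far as these compounds go, is whether the lower number depends on the benzyl ring itself or on any replacement of the hydroxy hydrogen, a question that a methyl group, a longer alkyl chain or a chain ending in an amine on the same oxygen could address. Also open, from the compounds shown here alone, is whether the same change would carry over to the cores of compound 1 and compound 3, which already hold benzyl on the corresponding oxygen and differ from compound 2 in several further places.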